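Hydroxy in Place of Methyl on the Ketone-Bearing Ring

This account rests on a few compounds, and the source may have more. Where it says the series, first, only, none or still open, it means among the compounds named here.

Three compounds share a flexible linker between two aromatic rings. Compound 1 `Cc1cc(C(=O)O)ccc1OCCCCOc1ccc(C(=O)CC(C)C)c(O)c1C` gives 192 nM in an assay on HEK293 cells for positive allosteric modulation of metabotropic glutamate receptor 2 (Rattus norvegicus), read by thallium flux, with a stated time of 2.5 min; a higher number here means that more compound is needed for the effect, a lower number that less compound is needed. Compound 2 `COC(=O)c1ccc(OCCCCOc2ccc(C(=O)CC3CCCC3)c(O)c2C)cc1` is reported as "not determined" (no result reported) in this assay. Compound 3 `Cc1c(OCCCCOc2ccccc2C(=O)O)ccc(C(=O)CC2CCCC2)c1C` gives 2580 nM in this assay, the highest of the two numbers in hand, and its gap to compound 1 lies beyond the usual scatter. Compound 4 `Cc1c(OCCCCOc2ccccc2C(=O)O)ccc(C(=O)CC2CCCC2)c1O` differs from compound 3 by hydroxy in place of methyl on an aromatic carbon. For the measured compounds named here, no two measured compounds differ in a single place, so no step has been measured directly. Because compound 1 gives 192 nM while also carrying a hydroxy on its core, the step of a 5.2-fold lower number from compound 3 to compound 4 (0.71 log units; beyond the scatter) is expected to lower the number well beyond the scatter. Compound 4 is therefore estimated at 500 nM, between 150 nM and 1600 nM.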

Compound 4, half-maximal effective concentration: 335 nM
Beside the measured number, compound 4's estimate is 1.5-fold (0.17 log units) above it, and the stated range covers the measured number.
By their numbers in this assay, from the lowest: compounds 1 and 4 (each within the scatter of the next); then compound 3.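

For the compounds shown here, the step of a 7.7-fold lower number from compound 3 to compound 4 (0.89 log units; beyond the scatter) in this assay is the first direct reading of a single change. It shows that the aromatic carbon ortho to the (cyclopentylmethyl)carbonyl group responds to the exchange of one heavy atom, with hydroxy in place of methyl. Nothing at hand explains this step.

The compounds shown leave open how a methoxy or an amine would read on this same carbon. They also leave open whether the same exchange would give a similar step with a different chain on the ketone.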